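Widening the amine chains on the shared core

This account rests on a few compounds, and the source may have more. Where it says the series, first, only, none or still open, it means among the compounds named here.

Among the compounds with values here, in a functional assay on CHO cells for agonist activity at Melanocortin receptor 4 (Homo sapiens), read by cAMP accumulation (a lower number here means that less compound is needed, a higher number that more compound is needed for the effect), compound 1 (`CCCN(CCC)CC(C1CCCCC1)N1CCN(C(=O)[C@@H]2CN(C(C)(C)C)C[C@H]2c2ccc(F)cc2F)CC1`) gives 710 nM, which is the only number it has in this assay, with one further entry that reports no single value. The other measured compound 2 (`CC(=O)N(CC(C1CCCCC1)N1CCN(C(=O)[C@@H]2CN(C(C)(C)C)C[C@H]2c2ccc(F)cc2F)CC1)C(C)C`) gives 25 nM; 50 nM (2 entries) in this assay, and the repeated entries of compound 2 (the several entries of compound 2 in this assay, 25 nM; 50 nM (2 entries)) show how far its own readings spread. Compound 3 (`CC(C)CN(CC(C)C)CC(C1CCCCC1)N1CCN(C(=O)[C@@H]2CN(C(C)(C)C)C[C@H]2c2ccc(F)cc2F)CC1`) departs from compound 1 by one change: diisobutylamino in place of dipropylamino on a saturated chain carbon, two bonds along the chain from an amine nitrogen in a ring and a saturated ring carbon. Within the data shown here, no measured step of this kind is available, so the size of the change is open. Compound 3 is expected to land near compound 1, with a step from compound 1 of a 1.3-fold higher number from compound 1 to compound 3 (0.10 log units; within the scatter), not clearly beyond the scatter. The estimated value of compound 3 in this assay is 900 nM, between 250 nM and 3500 nM.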

Compound 3, half-maximal effective concentration: 6700 nM
The estimate for compound 3 lay 7.4-fold (0.87 log units) below the measured number, outside the stated range (above it).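

In this assay, this position on a saturated chain carbon proves sensitive to the form of the amine chains: exchanging dipropylamino for diisobutylamino gives a 9.4-fold higher number from compound 1 to compound 3 (0.97 log units; beyond the scatter), so the amine substituent here cannot be widened freely. The change is modest in atom count, from 7 to 9 heavy atoms, with no change in the count of hydrogen-bond donors or acceptors, yet much more compound is needed for the effect. This step clearly exceeds the spread seen between repeated readings of a single compound: the several entries of compound 2 in this assay, 25 nM; 50 nM (2 entries).

The compounds shown leave open whether the loss follows the branching of the isobutyl chains or simply their added carbons, a question that dibutylamino at the same position could separate. They also leave open whether a shorter group such as diethylamino would lower the number.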